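This account rests on a few compounds, and the source may have more. Where it says the series, first, only, none or still open, it means among the compounds named here.

In a physicochemical assay for pharmacokinetics, read by LC-MS, in phosphate buffer, at pH 7.4, in the presence of a further agent that is not named here (on this read-out lower numbers stand for a shorter-lived compound and higher numbers for a longer-lived compound), compound 2 `C=CC(=O)N1CC(NC(=O)Cn2cc(C(=O)N3CCc4cc(Cl)ccc4C3)c3cc(Br)ccc32)C1` gives 1.67 h and stands level, within the scatter, with compound 1 `C=CC(=O)N1CC(NC(=O)Cn2cc(C(=O)N3CCc4c(F)cccc4C3)c3cc(Br)ccc32)C1`, which in the same assay gives 1.67 h. For the measured compounds named here, the one measured step, no change at the digits printed from compound 1 to compound 2 (within the scatter), exchanged a fluorine-bearing group for a chlorine-bearing group on the carbonyl carbon and left the read-out unchanged.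

Compound 3 `C=CC(=O)N1CC(NC(=O)Cn2cc(C(=O)N(C)Cc3ccccc3)c3cc(Br)ccc32)C1` is not yet measured. Its change from compound 2 is a group of 9 heavy atoms (8 carbon, 1 nitrogen; one six-membered aromatic ring of carbon only) in place of a group of 11 heavy atoms (9 carbon, 1 nitrogen, 1 chlorine; one six-membered non-aromatic ring with 1 hetero atom, one six-membered aromatic ring of carbon only), on a carbonyl carbon. Going by the values given here, it touches the same carbonyl carbon as the measured step, but it is a wider rebuild than a halogen swap, so that step bears on it only loosely and no other step applies. The acrylamide itself is untouched, and on this basis no step beyond the scatter is expected, with a range widened to cover the thin evidence. For compound 3 the estimate in this assay is 1.7 h, with a range from 0.9 h to 3.2 h. This means an expected step of a 1.0-fold higher number from compound 2 to compound 3 (0.01 log units; within the scatter).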

Compound 3, half-life: 1.67 h
For compound 3 the middle estimate is 1.0-fold (0.01 log units) above the measured one; the measured number falls inside the stated range.
By their numbers in this assay, from the lowest: compounds 1, 2 and 3 (each within the scatter of the next).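

In this assay, the change at this carbonyl carbon now goes beyond a halogen swap: benzyl(methyl)amino gives no change at the digits printed from compound 2 to compound 3 (within the scatter) and, against the 5-fluoro-1,2,3,4-tetrahydroisoquinolin-2-yl group, no change at the digits printed from compound 1 to compound 3 (within the scatter). The non-aromatic ring and the halogen can therefore both go from the group on this carbonyl carbon without a shift in half-life beyond the scatter, at least across these three compounds. No supporting data are available to explain this result.

From the compounds shown here alone, it remains open whether a piperazine, or a benzyl group carrying a carboxylic acid, on this carbonyl carbon would move the half-life beyond the scatter. Going by these compounds, it is also open whether a change elsewhere, such as a propanamide in place of the acrylamide, would move it.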